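A cyclopropyl group gives way to methyl

The compounds below may be only part of what the source reports. "The series", "measured", "known", "first", "only" and "open" are said of these compounds alone.

Of the compounds shown here, two sharing one core have been tested so far for harm to cultured cells: compound 1 (`O=C(NCc1ccccn1)c1ncc([N+](=O)[O-])[nH]1`) and compound 2 (`O=C(NC1CC1)c1ncc([N+](=O)[O-])[nH]1`). In a toxicity assay on HepG2 cells (Homo sapiens) for inhibition, read by resazurin assay, with a stated time of 24 h (on this read-out higher numbers stand for lower toxicity in this test and lower numbers for higher toxicity in this test), compound 1 gives > 100000 nM as a limit of the assay and not a number. In this assay compound 2 gives > 100000 nM as a limit too. Going by the values given here, compound 2 therefore has no exact position and stands with the limit of > 100000 nM in this assay, at which 2 of the 2 values shown sit, as its only guide.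

The next compound is compound 3 (`CNC(=O)c1ncc([N+](=O)[O-])[nH]1`), which has methyl in place of cyclopropyl on an amide-type nitrogen, counted as methyl in place of cyclopropyl on an amide-type nitrogen for this single change. Among the compounds with values here, no measured pair shows a step of this kind, so any expectation has to be cautious. Within the data shown here, no change beyond the usual scatter is expected, in either direction, and the only support is the limit of > 100000 nM in this assay, at which 2 of the 2 values shown sit, in this assay so far. The expected size of the change is a step that the limit leaves unreadable from compound 2 to compound 3 in this estimate. For compound 3 the estimated value is 150000 nM with an expected range from 60000 nM to 400000 nM in this assay and a good chance of ending up as only a limit.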

Compound 3, half-maximal cytotoxic concentration: > 100000 nM
Compound 3: a limit, no number; the forecaster's own chance of this, stated with the estimate: 85%; the middle value lies beyond the limit too.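

In this assay, going by these compounds alone, compound 1, compound 2 and compound 3 all end at a limit of the assay and not a number, so no step among them can be read. The compounds shown leave open whether changing the group on the amide-type nitrogen alters toxicity to these cells, and at what concentration any of the three would harm them.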